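The source may hold more compounds than are shown below. What is called first, only, known or untested is meant among the compounds shown, and "the series" means these compounds.

Measured in a functional assay on MCF7 cells (Homo sapiens) for antiproliferative activity, read by MTT assay, with a stated time of 48 h; on this read-out higher numbers stand for weaker inhibition and lower numbers for stronger inhibition:

- compound 1 `Fc1ccc2[nH]c(-c3cn(-c4ccccc4)nc3-c3ccccc3)nc2c1`: 2430 nM
- compound 2 `Fc1ccc(-c2nn(-c3ccccc3)cc2-c2nc3cc(F)ccc3[nH]2)cc1`: 950 nM
- compound 3 `Clc1ccc(-c2nn(-c3ccccc3)cc2-c2nc3ccccc3[nH]2)cc1`: 3030 nM

Compound 3, at 3030 nM, lies within the usual scatter of compound 1, at 2430 nM. The gap from compound 3 to compound 2, at 950 nM, goes beyond that scatter, with compound 3 on the weaker side.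

The next compound to be tested is compound 4 `Fc1ccc2[nH]c(-c3cn(-c4ccccc4)nc3-c3ccc(Cl)cc3)nc2c1`. It differs from compound 3 by one small edit, fluoro in place of hydrogen on an aromatic carbon. Compound 1 and compound 2 already carry a fluoro at this place.

Going by the values given here, only one measured step bears on this edit: a 2.6-fold lower number from compound 1 to compound 2 (0.41 log units; beyond the scatter). It is the same kind of swap, but made elsewhere in the molecule, so it is only an indirect guide. It is also a single modest step, which makes any forecast loose. Even so, it points towards a lower number, and a step of similar modest size seems the best guess.

The expected change is a 2.3-fold lower number from compound 3 to compound 4 (0.37 log units; beyond the scatter). For compound 4 the estimated value is 1300 nM, with an expected range of 450 nM to 3500 nM.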

Compound 4, half-maximal inhibitory concentration: 2830 nM
Compound 4: middle estimate off by 2.2-fold (0.34 log units), on the low side; low and high end bracket the measured number.
By their numbers in this assay, from the lowest: compound 2; then compounds 1, 4 and 3 (each within the scatter of the next).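

In this assay, fluoro on this aromatic carbon of the fused ring makes no measurable difference when the other aromatic ring carries a chloro: a 1.1-fold lower number from compound 3 to compound 4 (0.03 log units; within the scatter). With the fluoro held in place, the group on that other ring does count, for the fluoro of compound 2 gives way to chloro with a 3.0-fold higher number from compound 2 to compound 4 (0.47 log units; beyond the scatter), whereas chloro in place of hydrogen leaves the number within the scatter, with a 1.2-fold higher number from compound 1 to compound 4 (0.07 log units; within the scatter), so among these fluoro-bearing compounds only compound 2 stands apart. The new step looks unlike the earlier one for the same swap, yet the two cannot be told apart, and a real dependence on the rest of the molecule is not shown: the same change on two cores in this assay, a 2.6-fold lower number (0.41 log units; beyond the scatter) from compound 1 to compound 2 and a 1.1-fold lower number (0.03 log units; within the scatter) from compound 3 to compound 4, 2.4-fold (0.38 log units) apart, within the scatter of two such steps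

Still open is whether the number of compound 2 needs fluoro on both rings, as the compounds shown do not separate the fluoro on the other ring from the fluoro on the fused ring. Also open, on these data alone, is how a methoxy group or an amine at this place on the fused ring would compare with fluoro and hydrogen.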